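Swapping fluoro for methoxy: what compound 3 may show

A few compounds are considered here, and "the series" means these few. Any claim that something is new, unique, unknown or untested is made for them only; others in the source may bear on it.

Measured in a functional assay on HeLa cells (Homo sapiens) for inhibition, read by CCK-8 assay, with a stated time of 72 h; on this read-out higher numbers stand for weaker inhibition and lower numbers for stronger inhibition:
compound 1 `Nc1ccccc1NC(=O)c1ccc(CNC(=O)c2n[nH]cc2NC(=O)c2ccccc2Cl)cc1`: 10500 nM
compound 2 `Nc1ccccc1NC(=O)c1ccc(CNC(=O)c2n[nH]cc2NC(=O)c2ccccc2F)cc1`: 3440 nM

Of these two, compound 2 at 3440 nM holds the lower number, and so the stronger inhibition. Compound 3 `COc1ccccc1C(=O)Nc1c[nH]nc1C(=O)NCc1ccc(C(=O)Nc2ccccc2N)cc1` carries methoxy in place of fluoro on an aromatic carbon, ortho to a large group: methoxy in place of fluoro on an aromatic carbon. Within the data shown here, the one measured step that bears on this change is a 3.1-fold lower number from compound 1 to compound 2 (0.48 log units; beyond the scatter), with fluoro in place of chloro on an aromatic carbon. Among the measured compounds shown here, that modest step suggests a size, but no methoxy compound has been measured, so direction remains uncertain. For the measured compounds named here, with only two values, a rise from the lower one seems slightly more likely. The expected change is a 1.5-fold higher number from compound 2 to compound 3 (0.16 log units; within the scatter), estimated as modest at most and leaning toward a higher number. Compound 3 is expected at 5000 nM, with an estimated range of 1700 nM to 14000 nM.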

Compound 3, half-maximal inhibitory concentration: 8130 nM
Compound 3: middle estimate off by 1.6-fold (0.21 log units), on the low side; the range from low to high includes it.
By their numbers in this assay, from the lowest: compound 2; then compounds 3 and 1 (each within the scatter of the next).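

In this assay, methoxy on an aromatic carbon, ortho to a large group, gives a weaker result than fluoro (a 2.4-fold higher number from compound 2 to compound 3 (0.37 log units; beyond the scatter)), so the lead of fluoro at this place now holds against a second group and not only against chloro. Methoxy and chloro cannot be told apart here (a 1.3-fold lower number from compound 1 to compound 3 (0.11 log units; within the scatter)), which leaves compound 2 as the strongest of the three, with the other two level. Nothing available bears on why fluoro stands apart from these two groups.

From the compounds shown here alone, whether an amine or a nitrile at the same place would match or pass compound 2 stays open. Also open, going by these compounds, is whether plain hydrogen in place of fluoro would show that fluoro itself helps, or that chloro and methoxy hold the inhibition back.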